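From amino to hydroxy: the step to compound 3

The compounds below may be only part of what the source reports. "The series", "measured", "known", "first", "only" and "open" are said of these compounds alone.

Compound 1 `COc1ccc(/C(F)=C(/Br)c2cc(OC)c(OC)c(OC)c2)cc1O`: > 200000 nM
Compound 2 `COc1ccc(/C(F)=C(/F)c2cc(OC)c(OC)c(OC)c2)cc1N`: 3600 nM

Of the compounds shown here, two have been measured so far in a functional assay on cells (Endothelial cell, Bos taurus) for antiproliferative activity; a lower number here means a stronger inhibitor, a higher number a weaker inhibitor. Compound 1 gives > 200000 nM, which is a limit of the assay and not a number. Among the measured compounds shown here, compound 2 gives 3600 nM, the only true number available, so it stands as the sole numerical reference point in this assay.

The next compound is compound 3 `COc1ccc(/C(F)=C(/F)c2cc(OC)c(OC)c(OC)c2)cc1O`, which has not yet been measured. It differs from compound 2 in one place: hydroxy in place of amino on an aromatic carbon. Hydroxy takes the place of amino on an aromatic carbon, ortho to a methoxy group and meta to a large group.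

For the measured compounds named here, no measured step shows what this exchange does in this assay. The expectation therefore rests on compound 2 with 3600 nM as its anchor. A small move toward a lower value is expected, possibly none beyond the scatter. The expected change is a 1.4-fold lower number from compound 2 to compound 3 (0.16 log units; within the scatter). For compound 3 the estimated value is 2500 nM, with an expected range from 300 nM to 20000 nM.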

Compound 3, half-maximal inhibitory concentration: 4600 nM
Compound 3: the middle estimate sits 1.8-fold (0.26 log units) below what was measured; low and high end bracket the measured number.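

In this assay, hydroxy in place of amino on an aromatic carbon, ortho to a methoxy group, gives a 1.3-fold higher number from compound 2 to compound 3 (0.11 log units; within the scatter), so this exchange at this position leaves the activity unchanged within the scatter, and either group is accepted there. The other step keeps hydroxy on the ring and changes the double-bonded chain carbon: fluoro in place of bromo gives an at least 43-fold lower number from compound 1 to compound 3 (1.63 log units; beyond the scatter), and of the two steps only this one lies beyond the scatter. The value of compound 1 is a limit of the assay and not a number, so this step has a bound and no exact size: the limit of > 200000 nM in this assay, at which 1 of the 3 values shown sits.

The compounds shown leave open whether amino and hydroxy would also stay level with bromo on the chain carbon, and whether an acetamide or a carboxylic acid on the same aromatic carbon would keep the activity of compound 3 at 4600 nM. Also open, going by these compounds, is whether chloro or hydrogen on the chain carbon would give a number closer to that of compound 3 or to the limit of compound 1.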